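The source may report more compounds than this note shows. Statements on the series, on what has been measured and on what is new or still open speak of the compounds shown alone.

In a functional assay on DU-145 cells (Homo sapiens) for cytotoxicity, read by MTT assay, with a stated time of 24 h (on this read-out higher numbers stand for weaker inhibition and lower numbers for stronger inhibition), compound 1 (`Cc1ccc(Cl)cc1S(=O)(=O)Nc1ccc(Cl)c(Cl)c1`) gives 45400 nM and compound 2 (`Cc1ccc(NS(=O)(=O)c2cc(Cl)sc2Cl)cc1`) gives 81100 nM so the two values lie within the scatter of each other. Compound 3 (`Cc1ccc(N(SC(Cl)(Cl)Cl)S(=O)(=O)c2cc(Cl)sc2Cl)cc1`) carries (trichloromethyl)sulfanyl in place of hydrogen on a sulfonamide nitrogen. Within the data shown here, no measured pair shows this change, so the expectation is only a judgment: a sizeable move toward lower numbers, meaning stronger inhibition in this assay and beyond the scatter. The estimated step is a 14-fold lower number from compound 2 to compound 3 (1.13 log units; beyond the scatter) and remains unconfirmed. Compound 3 is estimated at 6000 nM (expected range 1200 nM to 30000 nM).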

Compound 3, half-maximal inhibitory concentration: 53000 nM
Beside the measured number, compound 3's estimate is 8.8-fold (0.95 log units) below it, and the stated range ends below it.
By their numbers in this assay, from the lowest: compounds 1, 3 and 2 (each within the scatter of the next).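

In this assay, (trichloromethyl)sulfanyl in place of hydrogen on a sulfonamide nitrogen gives a 1.5-fold lower number from compound 2 to compound 3 (0.18 log units; within the scatter) and so leaves the read-out inside the scatter. Compounds 1 and 2 both keep hydrogen on this nitrogen, so they could not show that it tolerates such a group without a measurable difference. Nothing available explains this outcome. As far as these compounds go, whether a methyl or acetyl group on the same nitrogen would read alike remains open. So does whether (trichloromethyl)sulfanyl would behave the same way on the core of compound 1.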